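Cyclohexylamine linker variation on the shared core

This account rests on a few compounds, and the source may have more. Where it says the series, first, only, none or still open, it means among the compounds named here.

Of the compounds shown here, two of this core have been measured. In an assay on isolated protein for inhibition of protein kinase C delta type (Homo sapiens), read by TR-FRET, with a stated time of 2 h (a lower number here means a stronger inhibitor, a higher number a weaker inhibitor), compound 1 `N#Cc1cnc(NCc2cnccc2C(F)(F)F)cc1N[C@H]1CC[C@H](O)CC1` gives 6500 nM and compound 2 `CO[C@H]1CC[C@@H](Nc2cc(NCc3cnccc3C(F)(F)F)ncc2C#N)CC1` gives 5000 nM. The step of a 1.3-fold lower number from compound 1 to compound 2 (0.11 log units; within the scatter) is within the scatter, so compound 2 simply gives the lower of the two numbers without standing apart from compound 1.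

Compound 3 `N#Cc1cnc(NCc2cnccc2C(F)(F)F)cc1NC[C@H]1CC[C@@H](O)CC1` differs from compound 2 by (4-hydroxycyclohexyl)methyl in place of 4-methoxycyclohexyl on a nitrogen on an aromatic ring. The hydroxy-for-methoxy part of this change is covered by a 1.3-fold lower number from compound 1 to compound 2 (0.11 log units; within the scatter), which was within the scatter. For the measured compounds named here, the inserted methylene between the ring and the nitrogen has no measured counterpart, so its effect is unknown. On that basis no step beyond the scatter is expected, with wide uncertainty: the step from compound 2 to compound 3 is expected as a 1.2-fold higher number from compound 2 to compound 3 (0.08 log units; within the scatter). For compound 3 this assay is expected to give 6000 nM, with a range of 2000 nM to 20000 nM.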

Compound 3, half-maximal inhibitory concentration: 500 nM
The estimate for compound 3 lay 12-fold (1.08 log units) above the measured number; the measured number lies below the stated range.
By their numbers in this assay, from the lowest: compound 3; then compounds 2 and 1 (each within the scatter of the next).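

The length of the link to the nitrogen on the aromatic ring matters far more here than the cap on the ring oxygen. The change to (4-hydroxycyclohexyl)methyl gives a 13-fold lower number from compound 1 to compound 3 (1.11 log units; beyond the scatter) with the hydroxy group kept, and the comparison with the methoxy compound gives a 10-fold lower number from compound 2 to compound 3 (1.00 log units; beyond the scatter), whereas a 1.3-fold lower number from compound 1 to compound 2 (0.11 log units; within the scatter) showed no separation for the exchange of hydroxy and methoxy on the directly attached ring. Nothing available explains this shift in this assay.

From the compounds shown here alone, whether the (4-methoxycyclohexyl)methyl group keeps the lower number remains open, so the role of the free hydroxy group with the methylene link in place cannot yet be judged. Also open, going by these compounds, is how far the trend extends, whether to a longer chain on the same nitrogen or to an amine in place of the hydroxy group.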